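Methoxy for dimethyl on the sulfonyl aryl

The source may report more compounds than this note shows. Statements on the series, on what has been measured and on what is new or still open speak of the compounds shown alone.

Compound 1 `CC1CCN(C2CCN(S(=O)(=O)c3cccnc3Cl)CC2)CC1`: > 5000 nM
Compound 2 `CC1CCN(C2CCN(S(=O)(=O)c3cnc(Cl)s3)CC2)CC1`: 1800 nM
Compound 3 `Cc1ccc(S(=O)(=O)N2CCC(N3CCC(C)CC3)CC2)cc1C`: 24 nM

In a functional assay on DLD-1 cells (Homo sapiens) for antiproliferative activity, read by CellTiter-Glo, with a stated time of 72 h (a lower number here means a stronger inhibitor, a higher number a weaker inhibitor), compound 3 gives 24 nM, the lowest of the numbers shown. Compound 2 gives 1800 nM. For compound 1 the assay reports only a limit, > 5000 nM. Compound 4 `COc1cccc(S(=O)(=O)N2CCC(N3CCC(C)CC3)CC2)c1` has not yet been measured; it differs from compound 3 in one place: 3-methoxyphenyl in place of 3,4-dimethylphenyl on a sulfonyl sulfur. The measured steps at this position, an at least 200-fold lower number from compound 1 to compound 3 (2.31 log units; beyond the scatter) and a 75-fold lower number from compound 2 to compound 3 (1.88 log units; beyond the scatter), were large, and an at least 2.7-fold lower number from compound 1 to compound 2 (0.44 log units; beyond the scatter) at least modest, but each of them exchanged the whole aryl group for a different ring. The present change keeps the six-membered carbon ring and alters only its substituents, so a smaller step is expected. Compound 4 is therefore expected to give 80 nM, between 25 nM and 300 nM. That estimate means the step of a 3.3-fold higher number from compound 3 to compound 4 (0.52 log units; beyond the scatter), expected to lie toward a higher number.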

Compound 4, half-maximal inhibitory concentration: > 5000 nM
Compound 4 was reported as a limit (the forecaster's own chance of this, stated with the estimate: 3%); middle value at least 62-fold (1.79 log units) away from the limit.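

Keeping the six-membered carbon ring does not make this position forgiving: 3-methoxyphenyl in place of 3,4-dimethylphenyl on the sulfonyl sulfur gives an at least 200-fold higher number from compound 3 to compound 4 (2.31 log units; beyond the scatter). Compound 4 also trails the ring-exchanged compound, with an at least 2.7-fold higher number from compound 2 to compound 4 (0.44 log units; beyond the scatter). The step between compound 1 and compound 4 cannot be read.

Going by these compounds, it remains open whether the methoxy group or the missing methyl drives this change, and whether 3-methylphenyl or 3,4-dimethoxyphenyl on the same sulfur would stay near compound 3 at 24 nM. The true size of the step also stays open, since compound 4 is reported only as a limit: the limit of > 5000 nM in this assay, at which 2 of the 4 values shown sit.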